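The source may report more compounds than this note shows. Statements on the series, on what has been measured and on what is new or still open speak of the compounds shown alone.

Among the compounds with values here, the series so far is measured in a functional assay on the whole organism with Rattus norvegicus as the target, at a dose of 50 mg/kg by the oral route; a higher number here means more inhibition at the dose given (going by the name of the read-out), a lower number less inhibition. Compound 1 `CCOC(=O)c1c(Nc2ccc(OC)cc2)ncnc1NC(C)C` gives 62.7% in this assay. Compound 2 `CCOC(=O)c1c(NC(C)C)ncnc1Oc1ccccc1` gives 55.5% in this assay. Within the data shown here, these two numbers lie within the usual scatter of each other, so compound 1 cannot be set apart from compound 2 on this evidence; no other compound has been measured. Among the measured compounds shown here, no pair of measured compounds differs in one place, so no single-point step is known. Compound 3 `CCOC(=O)c1c(Nc2ccc([N+](=O)[O-])cc2)ncnc1NC(C)C` is not yet measured. It differs from compound 1 as follows: nitro in place of methoxy on an aromatic carbon. For the measured compounds named here, with no measured step of this kind to draw on, the expected step from compound 1 to compound 3 is small, a number 4.7 percentage points lower from compound 1 to compound 3 (within the scatter), in no direction beyond the scatter. Compound 3 is therefore expected to give about 58% in this assay, with a range from 35% to 80%.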

Compound 3, a percentage reported as inhibition, in the whole organism at one dose (the size of the read-out at that dose, not a potency): 84.6%
Compound 3: the middle estimate sits 26.6 percentage points below what was measured, and the stated range ends below it.
By their numbers in this assay, from the lowest: compounds 2 and 1 (each within the scatter of the next); then compound 3.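

Within this assay, the aromatic carbon para to a large group is now shown to be a place where one substitution moves the read-out: nitro in place of methoxy gives a number 21.9 percentage points higher from compound 1 to compound 3 (beyond the scatter). Within the data shown here, this is the only single-point step so far, and it sets compound 3 apart from compound 1 in a way the earlier comparison of compounds could not. The change alters the heavy-atom and hydrogen-bond acceptor counts together, and no measurement available here explains the step.

As far as these compounds go, whether the gain belongs to nitro itself remains open, since one pair cannot separate it from other groups at this place, such as an amine, a nitrile or a chlorine atom. Also open, from the compounds shown here alone, is whether nitro would give a similar step at another place on this ring.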